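The source may report more compounds than this note shows. Statements on the series, on what has been measured and on what is new or still open speak of the compounds shown alone.

In a functional assay on brain (Rattus norvegicus, strain Wistar) for inhibition (a lower number here means a stronger inhibitor, a higher number a weaker inhibitor), compound 1 (`CCCCCc1ccc(-c2c(C)[nH]c(=O)n2C)cc1`) gives 5900 nM, compound 2 (`CCCCCOc1ccc(-c2c(C)[nH]c(=O)n2C)cc1`) gives 4500 nM and compound 3 (`CCCCCCCc1ccc(-c2c(C)[nH]c(=O)n2C)cc1`) gives 8400 nM. Compound 3 therefore lies within the scatter of both others, and the three cannot be ranked. Compound 4 (`CCCCCCCCCCCCCCc1ccc(-c2c(C)[nH]c(=O)n2C)cc1`) lengthens the chain of compound 3 much further: heptyl in place of hydrogen on a saturated chain carbon, seven bonds along the chain from an aromatic carbon. Among the measured compounds shown here, the closest precedent is the shorter extension a 1.4-fold higher number from compound 1 to compound 3 (0.15 log units; within the scatter), which stayed within the scatter, as did a 1.3-fold lower number from compound 1 to compound 2 (0.12 log units; within the scatter) and a 1.9-fold higher number from compound 2 to compound 3 (0.27 log units; within the scatter). These steps point in no clear direction, so no step beyond the scatter is expected in this assay, and the estimate is a 1.1-fold lower number from compound 3 to compound 4 (0.02 log units; within the scatter). For compound 4 the estimated value is 8000 nM, with an expected range from 2500 nM to 30000 nM, kept wide since this extension goes well beyond anything measured.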

Compound 4, half-maximal inhibitory concentration: 43800 nM
Compound 4: middle estimate off by 5.5-fold (0.74 log units), on the low side; the measured number lies above the stated range.
By their numbers in this assay, from the lowest: compounds 2, 1 and 3 (each within the scatter of the next); then compound 4.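

In this assay, lengthening the chain finally has a visible effect: adding heptyl on a saturated chain carbon, seven bonds along the chain from an aromatic carbon, gives a 5.2-fold higher number from compound 3 to compound 4 (0.72 log units; beyond the scatter). Counted from the pentyl chain, the change is a 7.4-fold higher number from compound 1 to compound 4 (0.87 log units; beyond the scatter). So this position accepts small changes in chain length, but a much longer chain makes a weaker inhibitor, and no measurement here gives the reason. As far as these compounds go, it remains open at what chain length between these compounds the weakening begins. From the compounds shown here alone, it is also open how an amine or a carboxylic acid would behave in place of the added heptyl.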